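Working notes: cytotoxicity across a shared core

The source may report more compounds than this note shows. Statements on the series, on what has been measured and on what is new or still open speak of the compounds shown alone.

Measured in an ADME assay on HeLa cells (Homo sapiens) for cytotoxicity, read by MTT assay, with a stated time of 72 h; on this read-out lower numbers stand for higher toxicity in this test and higher numbers for lower toxicity in this test:
compound 1 `Fc1ccc(/C=N/c2sc3c(c2-c2nc4ccccc4s2)CCC3)cc1` gives 372 ug/mL
compound 2 `Fc1ccccc1/C=N/c1sc2c(c1-c1nc3ccccc3s1)CCC2` gives 355 ug/mL
compound 3 `Clc1ccc(/C=N/c2sc3c(c2-c2nc4ccccc4s2)CCC3)c(Cl)c1` gives 345 ug/mL

Compound 3 holds the lowest of the three numbers, but every gap is within the scatter: a 1.1-fold lower number from compound 1 to compound 3 (0.03 log units; within the scatter) and a 1.0-fold lower number from compound 2 to compound 3 (0.01 log units; within the scatter), and between the other two a 1.0-fold lower number from compound 1 to compound 2 (0.02 log units; within the scatter). The three measured compounds therefore read as one flat group in this assay.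

Compound 4 `C(=C/c1ccccc1)\C=N\c1sc2c(c1-c1nc3ccccc3s1)CCC2` has not been measured. Its change from compound 3 is 2-phenylethenyl in place of 2,4-dichlorophenyl on a carbon with a double bond to nitrogen. Within the data shown here, no measured step exchanges the aromatic ring on that carbon for a group with a double bond outside aromatic rings; the measured steps only shift or exchange halogens on that ring, and each of them stayed within the scatter. On that basis the expectation for compound 4 in this assay is a step of a 1.0-fold higher number from compound 3 to compound 4 (0.01 log units; within the scatter), not beyond the scatter. Compound 4 is estimated at 350 ug/mL, with a range from 200 ug/mL to 600 ug/mL.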

Compound 4, half-maximal cytotoxic concentration: 100 ug/mL
For compound 4 the middle estimate is 3.5-fold (0.54 log units) above the measured one; the whole stated range lies above it.
By their numbers in this assay, from the lowest: compound 4; then compounds 3, 2 and 1 (each within the scatter of the next).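

Among these compounds, replacing the halogen-bearing aromatic rings with 2-phenylethenyl on a carbon with a double bond to nitrogen gives the first change beyond the scatter in this assay. It shows up as a 3.5-fold lower number from compound 3 to compound 4 (0.54 log units; beyond the scatter) and as a 3.6-fold lower number from compound 2 to compound 4 (0.55 log units; beyond the scatter) and also as a 3.7-fold lower number from compound 1 to compound 4 (0.57 log units; beyond the scatter) in the same direction, towards higher toxicity in this test. This position therefore responds to a change of the group as a whole, although the halogen changes on the ring left the numbers flat, and no supporting data bear on the reason for the shift.

The compounds shown leave open whether the double bond outside aromatic rings is what matters, which 2-phenylethyl at the same place would address. Also open, on these data alone, is how a non-aromatic group such as cyclohexyl, or an amine on the aromatic ring, would read here.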